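The compounds below may be only part of what the source reports. "The series", "measured", "known", "first", "only" and "open" are said of these compounds alone.

Measured in a functional assay on MCF7 cells (Homo sapiens) for inhibition, with a stated time of 96 h; a higher number here means a weaker inhibitor, a lower number a stronger inhibitor:
- compound 1 `COc1cc(C(=O)c2cn(-c3cccc(C)c3)cc2-c2cccnc2)cc(OC)c1OC`: 52 nM
- compound 2 `COc1cc(C(=O)c2cn(-c3ccc(F)cc3)cc2-c2ccccn2)cc(OC)c1OC`: 73 nM

These two values lie within the usual scatter of each other, so compound 2 stands level with compound 1. Compound 3 `COc1cc(C(=O)c2cn(-c3ccc(F)cc3)cc2-c2cccnc2)cc(OC)c1OC` keeps the 4-fluorophenyl group of compound 2 and carries pyridin-3-yl in place of pyridin-2-yl on an aromatic carbon. Among the measured compounds shown here, no measured pair isolates this change. However, compound 1 also bears pyridin-3-yl and gives 52 nM, so no change beyond the scatter is expected in this assay. The expected step is small, a 1.5-fold lower number from compound 2 to compound 3 (0.16 log units; within the scatter). The estimate for compound 3 is 50 nM, with an expected range of 15 nM to 160 nM.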

Compound 3, half-maximal inhibitory concentration: 39 nM
Beside the measured number, compound 3's estimate is 1.3-fold (0.11 log units) above it; the measured number falls inside the stated range.
By their numbers in this assay, from the lowest: compounds 3, 1 and 2 (each within the scatter of the next).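

In this assay, pyridin-3-yl in place of pyridin-2-yl on this aromatic carbon gives a 1.9-fold lower number from compound 2 to compound 3 (0.27 log units; within the scatter) and so, in this first direct comparison at the position, the two pyridine attachments cannot be told apart. Likewise, 4-fluorophenyl in place of 3-methylphenyl on the aromatic nitrogen gives a 1.3-fold lower number from compound 1 to compound 3 (0.12 log units; within the scatter) and stays within the scatter. No supporting measurement bears on these results. Still open, going by these compounds, is whether a group other than a pyridine ring at this carbon, such as an amine or a carboxylic acid, would shift the number beyond the scatter.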